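The source may hold more compounds than are shown below. What is called first, only, known or untested is meant among the compounds shown, and "the series" means these compounds.

Compound 1 `O[C@@H]1[C@@H](O)[C@H](Oc2ccc3ccccc3c2)OC[C@H]1O` gives 91 uM; 363 uM (2 entries) in a functional assay on HCC70 cells (Homo sapiens) for antiproliferative activity, read by crystal violet staining, with a stated time of 96 h; on this read-out higher numbers stand for an effect only at larger amounts of compound and lower numbers for an effect already at smaller amounts.
Compound 2 `O[C@@H]1[C@@H](F)[C@H](Oc2ccc3ccccc3c2)OC[C@H]1O` gives 22 uM in this assay.

Among the numbers shown, compound 2 is the only compound with a single value in this assay; its other entry carries no number. Compound 1 spreads widely, as the entries the several entries of compound 1 in this assay, 91 uM; 363 uM (2 entries) show. Compound 3 `CO[C@H]1[C@H](Oc2ccc3ccccc3c2)OC[C@@H](O)[C@@H]1O` has not yet been measured. It differs from compound 2 by methoxy in place of fluoro on a saturated ring carbon. Going by the values given here, no measured pair shows this change, so the step of a 2.7-fold higher number from compound 2 to compound 3 (0.44 log units; beyond the scatter) is an expectation only: a modest shift toward larger amounts, not much beyond the scatter. Compound 3 is estimated at 60 uM, expected to fall between 20 uM and 200 uM.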

Compound 3, concentration for half-maximal effect: 127 uM
Estimate against measurement, compound 3: 2.1-fold (0.33 log units) below, within the range that was stated.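

In this assay, methoxy in place of fluoro on this saturated ring carbon gives a 5.8-fold higher number from compound 2 to compound 3 (0.76 log units; beyond the scatter), so the effect now needs clearly larger amounts of compound. Going by these compounds alone, this is the first measured pair to show that the read-out responds to which group sits at this position. Compound 3 at 127 uM falls inside the spread of compound 1, so those two cannot be put in order: the several entries of compound 1 in this assay, 91 uM; 363 uM (2 entries)

From the compounds shown here alone, what an amine or a longer chain such as ethoxy would do on this ring carbon stays open. So does whether this change would have the same effect in other cell lines.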